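The source may hold more compounds than are shown below. What is called first, only, known or untested is meant among the compounds shown, and "the series" means these compounds.

Measured compounds:
compound 1 `NS(=O)(=O)c1cc(-c2nnc(Cn3cc(-c4ccccc4)nn3)o2)c(Cl)cc1SCc1ccccc1`: 7000 nM
compound 2 `NS(=O)(=O)c1cc(-c2nnc(CNS(=O)(=O)c3ccc(Cl)cc3)o2)c(Cl)cc1SCc1ccccc1`: 24000 nM
compound 3 `NS(=O)(=O)c1cc(-c2nnc(/C=C/c3ccc(Cl)cc3)o2)c(Cl)cc1SCc1ccccc1`: 40000 nM

All three were tested in a functional assay on HeLa cells (Homo sapiens) for cytotoxicity, read by MTT assay, with a stated time of 72 h; on this read-out lower numbers stand for stronger inhibition and higher numbers for weaker inhibition. Compound 3 gives the highest number of the three; one of its gaps lies within the scatter (a 1.7-fold higher number from compound 2 to compound 3 (0.22 log units; within the scatter)), the other beyond it (a 5.7-fold higher number from compound 1 to compound 3 (0.76 log units; beyond the scatter)). Compound 4 `NS(=O)(=O)c1cc(-c2nnc(/C=C/c3ccc(Br)cc3)o2)c(Cl)cc1SCc1ccccc1` differs from compound 3 by bromo in place of chloro on an aromatic carbon. Going by the values given here, none of the measured steps exchanges one halogen for another: a 3.4-fold higher number from compound 1 to compound 2 (0.54 log units; beyond the scatter) and the two steps above each replace the whole chain on the shared core, so none bears directly on this change. With nothing to lean on, the expectation is a step of no change at the digits printed from compound 3 to compound 4 (within the scatter), that is, none beyond the scatter. Compound 4 is therefore estimated at 40000 nM, with a range from 15000 nM to 100000 nM.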

Compound 4, half-maximal inhibitory concentration: 29000 nM
For compound 4 the middle estimate is 1.4-fold (0.14 log units) above the measured one; the range from low to high includes it.
By their numbers in this assay, from the lowest: compound 1; then compounds 2, 4 and 3 (each within the scatter of the next).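

In this assay, going by these compounds alone, the exchange on the 4-chlorophenyl ring gives a first direct reading at this position (a 1.4-fold lower number from compound 3 to compound 4 (0.14 log units; within the scatter)), so bromo and chloro are not told apart here. The 2-(4-bromophenyl)ethenyl chain reads level with the (((4-chlorophenyl)sulfonyl)amino)methyl chain (a 1.2-fold higher number from compound 2 to compound 4 (0.08 log units; within the scatter)) and stays apart from the (4-phenyl-1H-1,2,3-triazol-1-yl)methyl chain (a 4.1-fold higher number from compound 1 to compound 4 (0.62 log units; beyond the scatter)), so the halogen exchange leaves both comparisons as they stood with chloro. No measurement is available that explains these steps.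

Open, as far as these compounds go, is whether a group other than a halogen at this position, such as an amine or a carboxylic acid, would give a step beyond the scatter. From the compounds shown here alone, a longer chain in place of the ethenyl link also remains open.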